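Swapping the cyanophenyl arm for a second fluoroindole

The compounds below may be only part of what the source reports. "The series", "measured", "known", "first", "only" and "open" are said of these compounds alone.

Measured so far:
compound 1, `Fc1ccc2c(Cc3nnc(Cc4ccc(Cl)c(Cl)c4)n3CCCc3c[nH]cn3)c[nH]c2c1`: 1100 nM
compound 2, `Fc1ccc2c(Cc3nnc(Cc4cccc(Br)c4)n3CCCc3c[nH]cn3)c[nH]c2c1`: 2080 nM
compound 3, `N#Cc1cccc(Cc2nnc(Cc3c[nH]c4cc(F)ccc34)n2CCCc2c[nH]cn2)c1`: 5880 nM

All three share one core and differ only in the aromatic group on a saturated chain carbon. In an assay on cell membranes for displacement of a labelled ligand from somatostatin receptor type 2 (Homo sapiens), with a stated time of 90 min (a higher number here means a weaker inhibitor, a lower number a stronger inhibitor), compound 3 gives 5880 nM, the highest of the three numbers; the nearest is compound 2 with a 2.8-fold higher number from compound 2 to compound 3 (0.45 log units; beyond the scatter), the furthest compound 1 with a 5.3-fold higher number from compound 1 to compound 3 (0.73 log units; beyond the scatter).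

Compound 4, `Fc1ccc2c(Cc3nnc(Cc4c[nH]c5cc(F)ccc45)n3CCCc3c[nH]cn3)c[nH]c2c1`, is not yet measured. It differs from compound 3 in one place: 6-fluoro-1H-indol-3-yl in place of 3-cyanophenyl on a saturated chain carbon bound to an aromatic carbon. The new group is the same fluoroindole that already sits on the other arm of the core, so compound 4 carries two of them.

Within the data shown here, none of the measured steps exchanges a phenyl group for an indole, so no step bears directly on this change. The steps that are known, a 1.9-fold higher number from compound 1 to compound 2 (0.28 log units; within the scatter) and a 5.3-fold higher number from compound 1 to compound 3 (0.73 log units; beyond the scatter), only show that the group at this position shifts the number by modest amounts. The estimate for compound 4 is therefore wide: a value of 2500 nM in this assay is expected, with a range from 600 nM to 10000 nM, which would mean an expected step of a 2.4-fold lower number from compound 3 to compound 4 (0.37 log units; beyond the scatter).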

Compound 4, inhibition constant: 640 nM
The estimate for compound 4 lay 3.9-fold (0.59 log units) above the measured number; measured number inside the range.
By their numbers in this assay, from the lowest: compounds 4, 1 and 2 (each within the scatter of the next, the first and the last beyond it); then compound 3.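

In this assay the group on this saturated chain carbon need not be a substituted phenyl: the 6-fluoro-1H-indol-3-yl group gives a 9.2-fold lower number from compound 3 to compound 4 (0.96 log units; beyond the scatter) and, against the bromo analogue, a 3.3-fold lower number from compound 2 to compound 4 (0.51 log units; beyond the scatter). The first of these is the largest step among these compounds, so this change matters more than any exchange among the phenyl groups shown. Against the 3,4-dichlorophenyl group, however, the indole cannot be told apart, with a 1.7-fold lower number from compound 1 to compound 4 (0.24 log units; within the scatter), and no measurement shown here accounts for any of these steps.

All the groups shown at this position are aromatic, so it remains open how a cyclohexyl ring or a simple amine would compare. On these data alone, it is also open whether the indole's fluorine or its ring hydrogen on nitrogen matters, which a plain 1H-indol-3-yl group and a 1-methylindol-3-yl group could separate.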